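A Protected Amino Group on the Compound 2 Chain

The source may hold more compounds than are shown below. What is called first, only, known or untested is meant among the compounds shown, and "the series" means these compounds.

- compound 1 `O=C(NNC(=O)c1ccc([N+](=O)[O-])o1)c1ccc([N+](=O)[O-])o1` gives 32000 nM
- compound 2 `O=C(Cc1ccccc1)NNC(=O)c1ccc([N+](=O)[O-])o1` gives 32000 nM

In a functional assay (Mus musculus) for cytotoxicity (a higher number here means that more compound is tolerated, a lower number that less compound is tolerated), compound 2 gives 32000 nM and stands level with compound 1 within the usual scatter. Compound 3 `CC(C)(C)OC(=O)N[C@@H](C(=O)NNC(=O)c1ccc([N+](=O)[O-])o1)c1ccccc1` follows from compound 2 through (tert-butoxycarbonyl)amino in place of hydrogen on a saturated chain carbon bound to an aromatic carbon and a carbonyl carbon with (tert-butoxycarbonyl)amino in place of hydrogen on a saturated chain carbon bound to an aromatic carbon and a carbonyl carbon. Going by the values given here, no measured pair shows what this change does in this assay so no step beyond the scatter is expected, in either direction. The expected change is a 1.1-fold lower number from compound 2 to compound 3 (0.03 log units; within the scatter) in this estimate. For compound 3 the estimated value is 30000 nM (range 12000 nM to 70000 nM).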

Compound 3, half-maximal cytotoxic concentration: 32000 nM
Compound 3: the middle estimate sits 1.1-fold (0.03 log units) below what was measured; the range from low to high includes it.
By their numbers in this assay, from the lowest: compounds 1, 2 and 3 (each within the scatter of the next).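

In this assay, (tert-butoxycarbonyl)amino in place of hydrogen on a saturated chain carbon bound to an aromatic carbon and a carbonyl carbon gives no change at the digits printed from compound 2 to compound 3 (within the scatter). This position thus carries a substituent of this size without a step beyond the scatter, something compound 1 and compound 2 could not show. Nothing available accounts for this result. Going by these compounds, what a free amine or a carboxylic acid on this carbon would give in this assay remains open. Also open, on these data alone, is whether any group at this position can move the number beyond the scatter.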